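From 3-(methylsulfanyl)phenyl to 4-(methylsulfanyl)phenyl in compound 4

The source may hold more compounds than are shown below. What is called first, only, known or untested is meant among the compounds shown, and "the series" means these compounds.

Compound 1 `C#Cc1cccc(NC(=O)CCc2cccc3c2B(O)OC3)c1`: > 100000 nM (a limit of the assay)
Compound 2 `O=C(CCc1cccc2c1B(O)OC2)Nc1cccc(-c2cccc(Cl)c2)c1`: 58000 nM
Compound 3 `CSc1cccc(-c2cccc(NC(=O)CCc3cccc4c3B(O)OC4)c2)c1`: 2000 nM

In an ADME assay on WI-38 cells (Homo sapiens) for cytotoxicity, read by MTT assay, with a stated time of 72 h (on this read-out lower numbers stand for stronger inhibition and higher numbers for weaker inhibition), compound 3 gives 2000 nM, the lowest number of the series. Its nearest neighbour is compound 2, which gives 58000 nM. Compound 1 stands at a limit and has no number: > 100000 nM.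

Compound 4 `CSc1ccc(-c2cccc(NC(=O)CCc3cccc4c3B(O)OC4)c2)cc1` has the same atoms as compound 3, joined differently: 4-(methylsulfanyl)phenyl in place of 3-(methylsulfanyl)phenyl on an aromatic carbon. It carries 4-(methylsulfanyl)phenyl in place of 3-(methylsulfanyl)phenyl on an aromatic carbon, meta to a large group.

Among the compounds with values here, no measured step moves a group in this way, so the evidence is indirect. The exchange of chloro for methylsulfanyl is large, a 29-fold lower number from compound 2 to compound 3 (1.46 log units; beyond the scatter), and so is an at least 50-fold lower number from compound 1 to compound 3 (1.69 log units; beyond the scatter). By contrast, the floor of an at least 1.7-fold lower number from compound 1 to compound 2 (0.23 log units; that floor lies within the scatter) lies within the scatter. These steps show that the number in this assay can respond strongly to a small change in this substituent, so a real shift cannot be ruled out. Compound 4 keeps the same group, however, so a smaller step is expected, most likely upward from the low number of compound 3. The expected change is a 2.5-fold higher number from compound 3 to compound 4 (0.40 log units; beyond the scatter). For compound 4 the estimated value is 5000 nM, with an expected range from 1300 nM to 25000 nM.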

Compound 4, half-maximal inhibitory concentration: 3800 nM
For compound 4 the middle estimate is 1.3-fold (0.12 log units) above the measured one, and the stated range covers the measured number.
By their numbers in this assay, from the lowest: compounds 3 and 4 (each within the scatter of the next); then compound 2. At a limit, above all of these: compound 1.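

Within the data shown here, exchanging 3-(methylsulfanyl)phenyl for 4-(methylsulfanyl)phenyl in this assay gives a 1.9-fold higher number from compound 3 to compound 4 (0.28 log units; within the scatter), so at this place, on an aromatic carbon meta to a large group, the two arrangements of the same atoms cannot be told apart, something the earlier compounds could not show. The large difference seen earlier between the methylsulfanyl and chloro compounds is thus not confined to the arrangement in compound 3, as the new compound also gives a 15-fold lower number from compound 2 to compound 4 (1.18 log units; beyond the scatter) and an at least 26-fold lower number from compound 1 to compound 4 (1.42 log units; beyond the scatter), although the step to compound 2 changes both the group and its arrangement. The last of these steps is only a floor, with compound 1 standing at a limit of the assay: the limit of > 100000 nM in this assay, at which 1 of the 4 values shown sits.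

As far as these compounds go, what an ethylsulfanyl, methoxy or dimethylamino group would do in place of methylsulfanyl remains open, as does the number that 4-chlorophenyl would give beside the 3-chlorophenyl of compound 2. From the compounds shown here alone, it also stays open how much of the low numbers of compound 3 and compound 4 belongs to the sulfur atom itself, and whether the same picture would hold in any other cell line.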